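Bromo for benzyloxy on a tetrasubstituted phenol core

The source may hold more compounds than are shown below. What is called first, only, known or untested is meant among the compounds shown, and "the series" means these compounds.

Three compounds sharing a phenol core were tested in an ADME assay on HEK293 cells (Homo sapiens) for cytotoxicity, read by MTT assay, with a stated time of 24 h; a higher number here means a weaker inhibitor, a lower number a stronger inhibitor. Compound 1 `Cc1cc(O)c(C(=O)/C=C/c2ccc(Cl)cc2)c(-c2ccc(OCc3ccccc3)cc2)c1C(=O)/C=C/c1ccc(Cl)cc1` is reported as "not active" (no number reported) with no number attached. Compound 3 `Cc1cc(O)c(C(=O)/C=C/c2ccc(OCc3ccccc3)cc2)c(-c2ccc(OCc3ccccc3)cc2)c1C(=O)/C=C/c1ccc(OCc2ccccc2)cc1` gives 30000 nM, and compound 2 `Cc1cc(O)c(C(=O)/C=C/c2ccc(OCc3ccccc3)cc2)c(-c2ccc(Br)cc2)c1C(=O)/C=C/c1ccc(OCc2ccccc2)cc1` gives 25000 nM. The change bromo in place of benzyloxy on an aromatic carbon produced a 1.2-fold lower number from compound 3 to compound 2 (0.08 log units; within the scatter). The difference between the cores of compound 1 and compound 3 is not broken down here. Compound 4 `Cc1cc(O)c(C(=O)/C=C/c2ccc(Cl)cc2)c(-c2ccc(Br)cc2)c1C(=O)/C=C/c1ccc(Cl)cc1` has not been measured; it arises from compound 1 by bromo in place of benzyloxy on an aromatic carbon, the same change in the same place, which occurs twice among these compounds. Because that change gave a 1.2-fold lower number from compound 3 to compound 2 (0.08 log units; within the scatter), a step of similar small size is expected from compound 1 to compound 4 in this assay. Since compound 1 gave no number, the estimate for compound 4 is 40000 nM, within 15000 nM and 120000 nM, and a limit rather than a number is considered quite possible.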

Compound 4, half-maximal inhibitory concentration: 25000 nM
Compound 4: middle estimate off by 1.6-fold (0.20 log units), on the high side, and the stated range covers the measured number.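

Among the compounds shown here, no step from compound 1 to compound 4 can be read in this assay: compound 1 carries no number. The compounds shown leave open whether bromo in place of benzyloxy acts alike on both cores. No evidence bears on this result.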